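Moving the ring nitrogen in the pyridylmethyl arm of compound 3

The source may report more compounds than this note shows. Statements on the series, on what has been measured and on what is new or still open speak of the compounds shown alone.

Compound 3, `Nc1ccccc1NC(=O)c1ccc(CSC(=S)N2CCN(Cc3ccncc3)CC2)cc1`, is one of three compounds sharing a core that were assessed in a functional assay on A-375 cells (Homo sapiens) for antiproliferative activity, read by CCK-8 assay, with a stated time of 72 h, tested at 2 uM (a lower number here means a weaker effect, a higher number a stronger effect of the compound at the concentration tested), where compound 3 gives 33.1%. Its neighbours are compound 1, `Nc1ccccc1NC(=O)c1ccc(CSC(=S)N2CCN(c3ccccc3)CC2)cc1`, which gives 27.5%, and compound 2, `Nc1ccccc1NC(=O)c1ccc(CSC(=S)N2CCN(c3cccnc3)CC2)cc1`, which gives 40.5%. On these numbers compound 3 sits between the other two, yet both of its gaps fall within the scatter: a number 5.6 percentage points higher from compound 1 to compound 3 (within the scatter) and a number 7.4 percentage points lower from compound 2 to compound 3 (within the scatter). Among the measured compounds shown here, the only step that stands out is a number 13 percentage points higher from compound 1 to compound 2 (beyond the scatter), which concerns an aryl placed directly on the ring nitrogen rather than a benzylic arm.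

Compound 4, `Nc1ccccc1NC(=O)c1ccc(CSC(=S)N2CCN(Cc3cccnc3)CC2)cc1`, is the unmeasured partner of compound 3; the change is pyridin-3-yl in place of pyridin-4-yl on a saturated chain carbon bound to an amine nitrogen in a ring. For the measured compounds named here, no measured pair reproduces this shift of the ring nitrogen within a pyridylmethyl group, so the nearest guides are the two small steps around compound 3, which stayed within the scatter. A step of no more than the scatter is therefore expected in this assay, with no firm direction, so that compound 4 is estimated at 35%, within a range from 24% to 47%, amounting to an expected a number 1.9 percentage points higher from compound 3 to compound 4 (within the scatter).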

Compound 4, a percentage reported as inhibition, at one concentration (the size of the read-out at that concentration, not a potency): 31.5%
Compound 4: the middle estimate sits 3.5 percentage points above what was measured; measured number inside the range.
By their numbers in this assay, from the lowest: compounds 1, 4, 3 and 2 (each within the scatter of the next, the first and the last beyond it).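

In this assay, the shift of the ring nitrogen from pyridin-4-yl to pyridin-3-yl, on a saturated chain carbon bound to an amine nitrogen in a ring, gives a number 1.6 percentage points lower from compound 3 to compound 4 (within the scatter), so this direct comparison finds no separation between the two pyridylmethyl isomers. The other two new steps, a number 9 percentage points lower from compound 2 to compound 4 (within the scatter) and a number 4 percentage points higher from compound 1 to compound 4 (within the scatter), also stay within the scatter, which means that compound 4, like compound 3, cannot be told apart from either compound 1 or compound 2, even though those two are separated by a number 13 percentage points higher from compound 1 to compound 2 (beyond the scatter). No measurement is available here that bears on the origin of any of these steps.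

What the compounds shown leave open is whether (pyridin-2-yl)methyl, a plain benzyl group or a longer chain in place of the methyl link would give a step beyond the scatter at this position. On these data alone, each reading also comes from a single concentration, so how these compounds would compare across a range of concentrations remains unknown.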